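A few compounds are considered here, and "the series" means these few. Any claim that something is new, unique, unknown or untested is made for them only; others in the source may bear on it.

Measured compounds:
compound 1 `Cc1ccccc1S(=O)(=O)NCc1ccc(CNC(=O)c2ccc(CNc3ncccn3)cc2)cc1` — an assay on MDA-MB-231 cells for binding affinity to C-X-C chemokine receptor type 4 (Homo sapiens), read by microscopy, with stated times of 10 min and 30 min; on this read-out higher numbers stand for an effect only at larger amounts of compound and lower numbers for an effect already at smaller amounts: 10 nM
compound 2 `O=C(NCc1ccc(CNS(=O)(=O)c2cccnc2)cc1)c1ccc(CNc2ncccn2)cc1` — this assay: > 1000 nM

The value of compound 2 is a limit of this assay, not a number; compound 2 therefore sits at the limit of > 1000 nM in this assay, at which 1 of the 2 values shown sits, the less potent end of the pair shown. Within the data shown here, the one measured step at the sulfonyl sulfur is an at least 100-fold higher number from compound 1 to compound 2 (2.00 log units; beyond the scatter), so the group on that sulfur is the position that decides the numbers here.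

Compound 3 `O=C(NCc1ccc(CNS(=O)(=O)c2ccccc2Cl)cc1)c1ccc(CNc2ncccn2)cc1` carries the change (2-chlorophenyl in place of pyridin-3-yl on a sulfonyl sulfur). Among the measured compounds shown here, the only relevant comparison is the measured step between compound 1 and compound 2, which was large, and compound 3 returns a carbon-only ring with a 2-substituent, as in compound 1, in place of the pyridin-3-yl of compound 2. The step from compound 2 to compound 3 is therefore expected to be large and downward in this assay, an at least 33-fold lower number from compound 2 to compound 3 (1.52 log units; beyond the scatter). The estimate for compound 3 is 30 nM, within 5 nM to 300 nM.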

Compound 3, effective concentration (reported as EC, without a stated level of effect): 1000 nM
Beside the measured number, compound 3's estimate is 33-fold (1.52 log units) below it, and the stated range ends below it.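

In this assay a carbon-only ring with a 2-substituent on the sulfonyl sulfur is not enough by itself: with chloro in place of methyl on an aromatic carbon there is a 100-fold higher number from compound 1 to compound 3 (2.00 log units; beyond the scatter). The earlier pair exchanged the whole ring, whereas this pair exchanges one substituent on it, so the numbers at this position answer to that single exchange and not only to the ring nitrogen of pyridin-3-yl. At the sulfonyl sulfur there is also a number no higher from compound 2 to compound 3 (the limit leaves the size open), and the size of this step cannot be read. Compound 2 stands at a limit and not at a number: the limit of > 1000 nM in this assay, at which 1 of the 3 values shown sits.

Open, as far as these compounds go, is whether the methyl of compound 1 is itself required, or whether an unsubstituted phenyl, a 2-ethylphenyl or a 2-methoxyphenyl on the sulfonyl sulfur would keep its number. Also open, from the compounds shown here alone, is how an amine or a carboxylic acid on that ring would read.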